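Working notes: from compound 3 to compound 4

This account rests on a few compounds, and the source may have more. Where it says the series, first, only, none or still open, it means among the compounds named here.

In an ADME assay on HEK293 cells (Homo sapiens) for cytotoxicity, read by ATP content, with a stated time of 6 h (a lower number here means that less compound is tolerated, a higher number that more compound is tolerated), compound 3 `COCCCNc1nc(N)nc2ccn(Cc3ccccn3)c12` gives > 24000 nM as a limit, not a number. Compound 1 `CCCCNc1nc(N)nc2ccn(Cc3cn4ccccc4n3)c12` gives > 24000 nM as a limit too. Compound 2 `CCCCNc1nc(N)nc2ccn(Cc3ccc4ccccc4n3)c12` also gives > 24000 nM as a limit. Compound 3 thus stands at the same limit as the other two, and no order among them can be read.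

Compound 4 `Nc1nc(NCc2ncco2)c2c(ccn2Cc2ccccn2)n1` carries one change on the shared core: 1,3-oxazol-2-yl in place of 2-methoxyethyl on a saturated chain carbon bound to a nitrogen on an aromatic ring with nothing else altered. For the measured compounds named here, no measured pair shows the size of such a change in this assay so no shift beyond the scatter is expected, in either direction. The expected size of a number no higher from compound 3 to compound 4 (the limit leaves the size open) is therefore close to nil. For compound 4 the estimate is 24000 nM with an expected range from 12000 nM to 48000 nM and a limit is the likeliest outcome.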

Compound 4, half-maximal cytotoxic concentration: > 24000 nM
Compound 4: a limit, no number (the forecaster's own chance of this, stated with the estimate: 85%); the middle value lies on the limit itself.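

Compound 3 and compound 4 both give a limit rather than a number, so no step between them can be read: the limit of > 24000 nM in this assay, at which 4 of the 4 values shown sit.

The compounds shown leave open how 1,3-oxazol-2-yl and 2-methoxyethyl compare in this assay.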